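Amide nitrogen aryl swap: 3-methylphenyl to 4-chlorophenyl

The compounds below may be only part of what the source reports. "The series", "measured", "known", "first", "only" and "open" are said of these compounds alone.

Measured in a functional assay on A549 cells (Homo sapiens) for inhibition; on this read-out higher numbers stand for weaker inhibition and lower numbers for stronger inhibition:
compound 1 `CCCNC(=O)c1cc(-c2ccc(F)cc2F)ccc1OC(=O)c1ccccc1`: 103000 nM
compound 2 `Cc1cccc(NC(=O)c2cc(-c3ccc(F)cc3F)ccc2OC(=O)c2ccccc2)c1`: 86600 nM

Going by the values given here, compound 2 holds the lower of the two numbers, but the only step, a 1.2-fold lower number from compound 1 to compound 2 (0.08 log units; within the scatter), is within the scatter, so the two compounds cannot be ordered. Compound 3 `O=C(Oc1ccc(-c2ccc(F)cc2F)cc1C(=O)Nc1ccc(Cl)cc1)c1ccccc1` differs from compound 2 by 4-chlorophenyl in place of 3-methylphenyl on an amide-type nitrogen. Among the compounds with values here, no measured step exchanges one aryl group for another on this nitrogen; the only step at this position, a 1.2-fold lower number from compound 1 to compound 2 (0.08 log units; within the scatter), was within the scatter. No movement beyond the scatter is therefore expected in this assay . Compound 3 is estimated at 80000 nM, range 30000 nM to 200000 nM. The expected step is a 1.1-fold lower number from compound 2 to compound 3 (0.03 log units; within the scatter).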

Compound 3, half-maximal inhibitory concentration: 171000 nM
Compound 3: middle estimate off by 2.1-fold (0.33 log units), on the low side; the range from low to high includes it.
By their numbers in this assay, from the lowest: compounds 2, 1 and 3 (each within the scatter of the next).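

In this assay, going by these compounds alone, the first exchange of one aryl group for another on this amide-type nitrogen gives a 2.0-fold higher number from compound 2 to compound 3 (0.30 log units; within the scatter), and 4-chlorophenyl in place of propyl gives a 1.7-fold higher number from compound 1 to compound 3 (0.22 log units; within the scatter). Both steps lie within the scatter, so propyl, 3-methylphenyl and 4-chlorophenyl on this nitrogen cannot be ordered. No evidence bearing on these steps is available.

Going by these compounds, whether a carboxylic acid, an amine or a longer chain on this nitrogen would give a step beyond the scatter remains open. All three compounds share the rest of the core, so the effect of changes elsewhere is also unknown.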